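Moving the ring nitrogen and adding a methyl on compound 3

This account rests on a few compounds, and the source may have more. Where it says the series, first, only, none or still open, it means among the compounds named here.

Three compounds have been measured in a functional assay on the whole organism for inhibition, with Rattus norvegicus as the target, read by paw edema, at a dose of 100 mg/kg by the oral route; a lower number here means less inhibition, a higher number more inhibition at the dose given (going by the name of the read-out):

Compound 1, `O=C(Nc1ccc(Cl)cc1)c1c(O)c2cccnc2n(-c2ccccc2)c1=O`, gives 11.6% in this assay.
Compound 2, `Nc1ccc(NC(=O)c2c(O)c3cccnc3n(-c3ccccc3)c2=O)cc1`, gives -5.5% in this assay.
Compound 3, `O=C(Nc1cccnc1)c1c(O)c2cccnc2n(-c2ccccc2)c1=O`, gives 30.3% in this assay.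

Compound 3 stands highest of the three; its nearest neighbour is compound 1, the step of a number 18.7 percentage points higher from compound 1 to compound 3 (beyond the scatter), and its furthest is compound 2, the step of a number 35.8 percentage points higher from compound 2 to compound 3 (beyond the scatter). Within the phenyl pair, a number 17.1 percentage points lower from compound 1 to compound 2 (beyond the scatter).

Compound 4, `Cc1cnccc1NC(=O)c1c(O)c2cccnc2n(-c2ccccc2)c1=O`, has not been measured. It differs from compound 3 in one place: 3-methylpyridin-4-yl in place of pyridin-3-yl on an amide-type nitrogen.

Going by the values given here, no measured step exchanges one pyridyl for another, and none adds a methyl, so nothing bears directly on this change. The two steps that touch the same amide-type nitrogen, a number 18.7 percentage points higher from compound 1 to compound 3 (beyond the scatter) and a number 35.8 percentage points higher from compound 2 to compound 3 (beyond the scatter), show that the group at this position matters, but both compare a pyridyl with a phenyl. For compound 4 a step of a number 5.3 percentage points lower from compound 3 to compound 4 (within the scatter) in this assay is expected, within the scatter. Compound 4 is estimated at 25%, in a range from 5% to 45%.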

Compound 4, a percentage reported as inhibition, in the whole organism at one dose (the size of the read-out at that dose, not a potency): 26.9%
Compound 4: the middle estimate sits 1.9 percentage points below what was measured; the range from low to high includes it.
By their numbers in this assay, from the lowest: compound 2; then compound 1; then compounds 4 and 3 (each within the scatter of the next).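

In this assay, the step of a number 3.4 percentage points lower from compound 3 to compound 4 (within the scatter) shows that a second kind of pyridyl, here carrying a methyl, can take the place of pyridin-3-yl on this amide-type nitrogen without a change beyond the usual spread of repeat measurements. The phenyl compounds stay apart from it too, with a number 32.4 percentage points higher from compound 2 to compound 4 (beyond the scatter) and a number 15.3 percentage points higher from compound 1 to compound 4 (beyond the scatter) in the same assay, so both pyridyl compounds now stand clear of both substituted phenyl compounds. No measurement on hand explains these steps.

The compounds shown do not separate the methyl from the place of the ring nitrogen, as both differ at once in compound 4. Plain pyridin-4-yl without the methyl, or an ethyl in place of the methyl, would pull those two apart.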